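A few compounds are considered here, and "the series" means these few. Any claim that something is new, unique, unknown or untested is made for them only; others in the source may bear on it.

Measured so far in an ADME assay on RAW264.7 cells (Mus musculus) for cytotoxicity, read by MTT assay, with a stated time of 24 h, in the presence of a further agent that is not named here (on this read-out lower numbers stand for stronger inhibition and higher numbers for weaker inhibition), each value being a limit and not a number:
- compound 1 `O=C1OC(Cc2nc(-c3ccccc3)no2)c2ccccc21`: > 40000 nM
- compound 2 `CCOc1ccc(C(O)C2OC(=O)c3c(OC)cc(OC)cc32)cc1`: > 40000 nM
- compound 3 `CCCOc1ccc(C(O)C2OC(=O)c3c(OC)cc(OC)cc32)cc1`: > 40000 nM

Not yet measured: compound 4 `COCCCOc1ccc(C(O)C2OC(=O)c3c(OC)cc(OC)cc32)cc1`.

Compound 3 stands only at its limit of > 40000 nM. It shares that position with the rest of the set, which shows (the limit of > 40000 nM in this assay, at which 3 of the 3 values shown sit). No measured number therefore anchors the series.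

The change to compound 4 is methoxy in place of hydrogen on a saturated chain carbon, three bonds along the chain from an oxygen on an aromatic ring, which turns propyl into 3-methoxypropyl.

Among the compounds with values here, the one measured step on this same chain is a step that the two limits leave unreadable from compound 2 to compound 3. It gives no size to carry over, but it also shows no departure from the limit when the chain is extended. Within the data shown here, compound 1 has no measured step to the others and adds only its own limit.

No step beyond the usual scatter is expected, in either direction, and a further limit is the likeliest report. The expected step is a number no higher from compound 3 to compound 4 (the limit leaves the size open). For compound 4 the estimate in this assay is 40000 nM, with an expected range of 20000 nM to 80000 nM.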

Compound 4, half-maximal inhibitory concentration: > 40000 nM
Compound 4: no number, only a limit (the forecaster's own chance of this, stated with the estimate: 85%); the middle value sits exactly at the limit.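

Compound 2, compound 3 and compound 4 each carry only a limit, so the steps from compound 2 and from compound 3 to compound 4 cannot be read. The compounds shown leave open whether propyl to 3-methoxypropyl changes anything in this assay, and how any compound would read as a number: the limit of > 40000 nM in this assay, at which 4 of the 4 values shown sit.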